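Adding a Dimethylaminoethyl Arm to Compound 2

The source may hold more compounds than are shown below. What is called first, only, known or untested is meant among the compounds shown, and "the series" means these compounds.

Compound 2 `CCCC(=O)OCSc1ccccc1C(=O)NCC(N)=O` was tested in an ADME assay on CEM-SS cells (Homo sapiens) for cytotoxicity, read by XTT assay, with a stated time of 6 days; a higher number here means that more compound is tolerated, a lower number that less compound is tolerated. In this assay compound 2 gives > 100 uM, which is a limit of the assay rather than a number. Two relatives were measured alongside it. Compound 3 `CCCC(=O)OCSc1ccccc1C(=O)N(C)CC(=O)N(C)C` gives 57.3 uM in this assay, and the step of an at least 1.7-fold lower number from compound 2 to compound 3 (0.24 log units; that floor lies within the scatter). Compound 1 `CCCC(=O)OCSc1ccc(OC(F)(F)F)cc1C(=O)NC(C)(C)C(N)=O` gives < 56.1 uM, also a limit. Compound 4 `CCCC(=O)OCSc1ccccc1C(=O)NCC(=O)NCCN(C)C` is not yet measured and differs from compound 2 by 2-(dimethylamino)ethyl in place of hydrogen on an amide-type nitrogen. Going by the values given here, no measured step adds a group to this nitrogen; the nearest comparison, an at least 1.7-fold lower number from compound 2 to compound 3 (0.24 log units; that floor lies within the scatter), changes what sits there and stays within the scatter, while compound 2 itself is only a limit. The expected step is therefore no larger than the scatter, an at least 1.1-fold lower number from compound 2 to compound 4 (0.07 log units; that floor lies within the scatter). Compound 4 is estimated at 85 uM, between 40 uM and 150 uM.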

Compound 4, half-maximal toxic concentration: 76.9 uM
Compound 4: the middle estimate sits 1.1-fold (0.04 log units) above what was measured; the range from low to high includes it.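

In this assay, going by these compounds alone, the first measured step that adds a group to this amide-type nitrogen is an at least 1.3-fold lower number from compound 2 to compound 4 (0.11 log units; that floor lies within the scatter). Within the data shown here, the value of compound 2 is a limit, so only a floor can be read for this step: the limit of > 100 uM in this assay, at which 1 of the 4 values shown sits. Compound 4 therefore gives the first actual number for a compound carrying 2-(dimethylamino)ethyl on this nitrogen.

The compounds shown do not separate the amine from the chain that carries it. A plain ethyl chain or a chain bearing a carboxylic acid on this nitrogen remains an open comparison.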